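Reworking the Side Chain of Compound 3

A few compounds are considered here, and "the series" means these few. Any claim that something is new, unique, unknown or untested is made for them only; others in the source may bear on it.

In an ADME assay on HOS cells (Homo sapiens) for cytotoxicity (on this read-out lower numbers stand for higher toxicity in this test and higher numbers for lower toxicity in this test), three compounds sharing one core have been measured. Compound 1 `CN(Cc1nc2cccc(C(=O)NCCCN)c2[nH]1)C1CCCc2cccnc21` gives > 20000 nM as a limit of the assay and not a number. Compound 2 `CN(Cc1nc2cccc(C(=O)NCCCCN)c2[nH]1)C1CCCc2cccnc21` gives > 20000 nM as a limit too. Compound 3 `CN(Cc1nc2cccc(CNCCN)c2[nH]1)C1CCCc2cccnc21` gives > 20000 nM as a limit as well, so it stands with the other two (the limit of > 20000 nM in this assay, at which 3 of the 3 values shown sit) on the numbers shown.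

Compound 4 `CN(C)CCCc1cccc2nc(CN(C)C3CCCc4cccnc43)[nH]c12` has not been measured yet. It differs from compound 3 on a saturated chain carbon bound to an aromatic carbon (2-(dimethylamino)ethyl in place of (2-aminoethyl)amino on a saturated chain carbon bound to an aromatic carbon) and the same difference, cut one bond further out, reads ((2-aminoethyl)amino)methyl to 3-(dimethylamino)propyl.

Two measured steps also rework this side chain (a step that the two limits leave unreadable from compound 1 to compound 3 and a step that the two limits leave unreadable from compound 2 to compound 3) and a third alters the amide chain (a step that the two limits leave unreadable from compound 1 to compound 2) in the same region. None of them has a readable size, so they give no direction.

With compound 3 at > 20000 nM as a limit, no step beyond the usual scatter is expected in this assay for this change. The estimated change is small (a number no higher from compound 3 to compound 4 (the limit leaves the size open)) with no favoured direction. The estimated value for compound 4 is 20000 nM with an expected range from 9000 nM to 40000 nM and the assay may well report only a limit again.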

Compound 4, half-maximal cytotoxic concentration: 7500 nM
Estimate against measurement, compound 4: 2.7-fold (0.43 log units) above, outside the stated range (below it).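

For the compounds shown here, compound 4 gives the first true number in this set, so this assay now shows that reworking this side chain can move the read-out: the change reads as an at least 2.6-fold lower number from compound 3 to compound 4 (0.42 log units; beyond the scatter) and points towards higher toxicity in this test. The two amide compounds point the same way, with an at least 2.6-fold lower number from compound 2 to compound 4 (0.42 log units; beyond the scatter) and an at least 2.6-fold lower number from compound 1 to compound 4 (0.42 log units; beyond the scatter) as the steps that replace each carbamoyl chain with 3-(dimethylamino)propyl, so all three readable steps agree, though each gives only a lower bound on size. The steps among compounds 1, 2 and 3 cannot be read because all three sit at a limit of the assay: the limit of > 20000 nM in this assay, at which 3 of the 4 values shown sit.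

Compound 4 differs from compound 3 in more than one feature at once, since the entering group has no hydrogen-bond donors and one nitrogen, while the leaving group has two of each, so the set cannot say which feature matters. A 3-aminopropyl or 3-(methylamino)propyl chain on the same carbon, or a longer chain ending in a dimethylamino group, would help to separate the effect of the end group from that of the chain nitrogen.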